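Methoxycarbonyl in Place of Ethyl on Compound 1

The compounds below may be only part of what the source reports. "The series", "measured", "known", "first", "only" and "open" are said of these compounds alone.

Measured compounds:
compound 1 `CCc1ccc(-c2nc(C(=O)c3cc(OC)c(OC)c(OC)c3)cs2)cc1` gives 31 nM here
compound 2 `CCCCCCCCCCCCCCCCNC(=O)[C@@H]1CSC(c2ccc(NC(C)=O)cc2)N1` gives 1700 nM here

Both numbers come from a functional assay on DU-145 cells (Homo sapiens) for cytotoxicity, read by sulforhodamine B assay, with a stated time of 48 h (on this read-out lower numbers stand for stronger inhibition and higher numbers for weaker inhibition), and can be compared directly. Compound 1, at 31 nM in this test, holds the lower of the two numbers, and the gap up to compound 2 lies beyond the usual scatter. The two structures differ in many places, so that gap says nothing about any single group.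

The next compound to be tested is compound 3 `COC(=O)c1ccc(-c2nc(C(=O)c3cc(OC)c(OC)c(OC)c3)cs2)cc1` with the core of compound 1 kept and methoxycarbonyl in place of ethyl on an aromatic carbon. The change is counted as methoxycarbonyl in place of ethyl on an aromatic carbon and sits para to a large group.

For the measured compounds named here, no measured pair here shows the effect of one single change, so any forecast is loose. Compound 1 already stands low at 31 nM and a modest loss seems likelier than a gain. In this assay the expected move is a 3.9-fold higher number from compound 1 to compound 3 (0.59 log units; beyond the scatter) towards weaker inhibition. Compound 3 is estimated at 120 nM with an expected range from 35 nM to 500 nM in this test.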

Compound 3, half-maximal inhibitory concentration: > 20000 nM
Compound 3 gave a limit, no number; the forecaster's own chance of this, stated with the estimate: 5%; middle value at least 160-fold (2.22 log units) away from the limit.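

In this assay, compound 3 gave a limit of the test and not a number: the limit of > 20000 nM in this assay, at which 1 of the 3 values shown sits. Even so, putting methoxycarbonyl in place of ethyl on this aromatic carbon, para to a large group, gives an at least 640-fold higher number from compound 1 to compound 3 (2.80 log units; beyond the scatter), and this is the first step in the set that follows one single change. It shows that this position is far from indifferent to what sits on it: with the rest of compound 1 kept, exchanging one small group for another is enough to carry the read-out from the low nanomolar range to beyond what the test reports.

This one pair cannot tell whether the loss follows from the larger group, from its carbonyl and ester oxygens, or from something outside the structure, such as how the compound behaves in the cells. It also leaves open how narrow the demand at this carbon is, since a methoxy group, an amine, a carboxylic acid or a longer chain there could each land anywhere from near compound 1 to the limit seen for compound 3.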